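The source may report more compounds than this note shows. Statements on the series, on what has been measured and on what is new or still open speak of the compounds shown alone.

Three compounds of one family appear here. Compound 1 `Oc1ccc(-c2cc(-c3cccnc3)nc(-c3ccccc3Cl)c2)cc1`, compound 2 `Oc1cccc(-c2cc(-c3ccc(Cl)cc3)nc(-c3ccco3)c2)c1` and compound 3 `Oc1cccc(-c2cc(-c3ccncc3)nc(-c3ccccc3Cl)c2)c1` share a core that carries three aromatic groups, and they were examined in an ADME assay on HEK293 cells (Homo sapiens) for cytotoxicity, read by CCK-8 assay and cell counting, with a stated time of 2 days; on this read-out higher numbers stand for weaker inhibition and lower numbers for stronger inhibition. Compound 2 gives 8190 nM in this assay. In this assay compound 1 gives "not determined" (no result reported). In the same assay compound 3 gives "not determined" (no result reported), so compound 3 stands without a single number, and the only figure available for the family comes from compound 2.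

Compound 4 `Oc1cccc(-c2cc(-c3ccco3)nc(-c3ccccc3Cl)c2)c1` is the next member and has yet to be measured in this assay. It differs from compound 3 in one place (furan-2-yl in place of pyridin-4-yl on an aromatic carbon). Compound 2 already holds a furan-2-yl group on its core together with a 3-hydroxyphenyl group, which makes its value the nearest point of reference. Among the compounds with values here, no measured step covers this change, so the expectation for compound 4 rests on compound 2 alone, with no direction of change beyond the scatter assumed. Compound 4 is expected to give about 8000 nM in this assay, with a likely range from 3000 nM to 25000 nM.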

Compound 4, half-maximal inhibitory concentration: 1860 nM
The estimate for compound 4 lay 4.3-fold (0.63 log units) above the measured number; the measured number lies below the stated range.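

In this assay, within the data shown here, putting 2-chlorophenyl in place of 4-chlorophenyl while the rest of the molecule stays the same gives a 4.4-fold lower number from compound 2 to compound 4 (0.64 log units; beyond the scatter), the first step in this family that can be read. The number therefore depends on where the chlorine sits on this phenyl group, and not only on its presence. Nothing available here explains why the 2-chlorophenyl group gives the lower number.

Among these compounds, compound 3 and compound 1 have no number, so no step involving them can be read, and the effect of furan-2-yl in place of pyridin-4-yl remains unknown. From the compounds shown here alone, it also remains open how this position would respond if the chlorine were replaced by a fluorine, a methoxy group or an amine.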